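The source may report more compounds than this note shows. Statements on the series, on what has been measured and on what is new or still open speak of the compounds shown alone.

The measured compounds:

Compound 1 `COc1ccc(C(O)C2OC(=O)c3c(OC)cc(OC)cc32)cc1` — in an ADME assay on RAW264.7 cells (Mus musculus) for cytotoxicity, read by MTT assay, with a stated time of 24 h, in the absence of a further agent (on this read-out lower numbers stand for stronger inhibition and higher numbers for weaker inhibition), compound 1 gives > 40000 nM, which is a limit of the assay.
Compound 2 `CCCCOc1ccc(C(O)C2OC(=O)c3c(OC)cc(OC)cc32)cc1` — in this assay compound 2 gives > 40000 nM, again a limit.
Compound 3 `CCCCCCOc1ccc(C(O)C2OC(=O)c3c(OC)cc(OC)cc32)cc1` — in this assay compound 3 gives > 40000 nM, also a limit.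

Compound 2 therefore stands only at a limit in this assay; no number is known for it, and the two other values shown are limits as well. All three sit at the limit of > 40000 nM in this assay, at which 3 of the 3 values shown sit.

The unmeasured compound 4 `COc1cc(OC)c2c(c1)C(C(O)c1ccc(OCc3ccc(Br)cc3)cc1)OC2=O` differs from compound 2 by 4-bromophenyl in place of propyl on a saturated chain carbon bound to an oxygen on an aromatic ring.

Of the measured steps, those that touch the same saturated chain carbon bound to an oxygen on an aromatic ring are a step that the two limits leave unreadable from compound 1 to compound 2 and a step that the two limits leave unreadable from compound 1 to compound 3, and the chain extension a step that the two limits leave unreadable from compound 2 to compound 3 is likewise unreadable. None of them yields a size, since every value involved is a limit. Lengthening the chain at this place gave no reading below the limit, and nothing in the measured set shows whether exchanging propyl for 4-bromophenyl would move the value into the readable range.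

He therefore expects compound 4 to give about 60000 nM, most likely again as a limit, within 25000 nM to 150000 nM. The step that this estimate means, a step that the limit leaves unreadable from compound 2 to compound 4, is expected to be none beyond the scatter.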

Compound 4, half-maximal inhibitory concentration: > 40000 nM
Compound 4: no number, only a limit (the forecaster's own chance of this, stated with the estimate: 75%); the middle value lies beyond the limit too.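

In this assay compound 4 also stands only at a limit, so its steps from compound 1, compound 2 and compound 3 cannot be read, and all four compounds sit together: the limit of > 40000 nM in this assay, at which 4 of the 4 values shown sit.

The compounds shown leave open what number any of the four would give, and whether any group at this place would bring a value into the readable range.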